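A few compounds are considered here, and "the series" means these few. Any claim that something is new, unique, unknown or untested is made for them only; others in the source may bear on it.

In a physicochemical assay for solubility, measured as kinetic solubility (a higher number here means a more soluble compound, a lower number a less soluble compound), compound 1 `Cc1ccc(Oc2cc(C(=O)Nc3cnc(C)cn3)cc3oc(C)cc23)cc1` gives 18000 nM and compound 2 `Cc1cnc(NC(=O)c2cc(Oc3ccc(C#N)cc3)c3cc(C)oc3c2)cn1` gives 2000 nM. Compound 3 `CCN(C)C(=O)c1cnc(Oc2cc(C(=O)Nc3cnc(C)cn3)cc3oc(C)cc23)cn1` gives 344000 nM, the highest number of the three and beyond the scatter from both others. Compound 4 `Cc1cnc(NC(=O)c2cc(Oc3cnc(C(=O)N4CCCC4)cn3)c3cc(C)oc3c2)cn1` differs from compound 3 in one place: pyrrolidin-1-yl in place of ethyl(methyl)amino on a carbonyl carbon. In words, pyrrolidin-1-yl stands in place of ethyl(methyl)amino on a carbonyl carbon. Going by the values given here, the only measured step, a 9.0-fold lower number from compound 1 to compound 2 (0.95 log units; beyond the scatter), is a modest one: cyano in place of methyl on an aromatic carbon. It does not touch this carbonyl group, so it offers only a loose guide to how far one swap can move the number. A small step in this assay is therefore expected, possibly none beyond the scatter, with a slight lean towards a lower number. The estimated change is a 1.4-fold lower number from compound 3 to compound 4 (0.14 log units; within the scatter). Compound 4 is expected at 250000 nM, with an estimated range from 100000 nM to 500000 nM.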

Compound 4, solubility: 4500 nM
Compound 4: the middle estimate sits 56-fold (1.74 log units) above what was measured, outside the stated range (below it).
By their numbers in this assay, from the lowest: compound 2; then compound 4; then compound 1; then compound 3.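

In this assay, pyrrolidin-1-yl in place of ethyl(methyl)amino on the carbonyl carbon gives a 76-fold lower number from compound 3 to compound 4 (1.88 log units; beyond the scatter), a large step. This position is therefore sensitive to the amine part of the amide, even though neither group has hydrogen-bond donors or acceptors or a net charge. No available evidence explains the step. The compounds shown cannot separate the effect of having a ring from the effect of its size. A piperidine or morpholine on the same carbonyl carbon could help settle that question.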